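Replacing the 3-carboxyazetidin-1-yl group of compound 3

A few compounds are considered here, and "the series" means these few. Any claim that something is new, unique, unknown or untested is made for them only; others in the source may bear on it.

Compound 1 `COc1ccc(/C=C\c2cc(OC)c(OC)c(OC)c2)cc1OCc1ccc(C=O)cc1` gives 46000 nM
Compound 2 `COc1ccc(/C=C\c2cc(OC)c(OC)c(OC)c2)cc1OCc1ccc(CNCCO)cc1` gives > 50000 nM (a limit)
Compound 3 `COc1ccc(/C=C\c2cc(OC)c(OC)c(OC)c2)cc1OCc1ccc(CN2CC(C(=O)O)C2)cc1` gives > 50000 nM (a limit)

All three values come from an ADME assay on HEK293 cells (Homo sapiens) for cytotoxicity, read by CCK-8 assay, with a stated time of 48 h (on this read-out higher numbers stand for weaker inhibition and lower numbers for stronger inhibition), and the two with a sign are limits, not numbers. Compound 3 stands at > 50000 nM as a limit of the assay, so its true value is not known. It belongs to the pair described by the limit of > 50000 nM in this assay, at which 2 of the 3 values shown sit, and has no readable rank against compound 2.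

Compound 4 `COc1ccc(/C=C\c2cc(OC)c(OC)c(OC)c2)cc1OCc1ccc(CN[C@H](C(=O)O)[C@@H](C)O)cc1` differs from compound 3 in one place ((1-carboxy-2-hydroxypropyl)amino in place of 3-carboxyazetidin-1-yl on a saturated chain carbon bound to an aromatic carbon). The four-membered non-aromatic ring leaves and no ring takes its place.

The closest measured comparison is a step that the two limits leave unreadable from compound 2 to compound 3 and it gives no size. Two further steps change the same place, an at least 1.0-fold higher number from compound 1 to compound 2 (0.03 log units; that floor lies within the scatter) and an at least 1.0-fold higher number from compound 1 to compound 3 (0.03 log units; that floor lies within the scatter) and neither shows a change beyond the scatter. Both amine side chains measured so far therefore reach the limit, and no step beyond the scatter is expected in this assay for the new side chain. The expected step is a step that the limit leaves unreadable from compound 3 to compound 4 and it is estimated to stay within the scatter. For compound 4 the estimated value is 60000 nM with an expected range from 30000 nM to 120000 nM and a report as a limit is the likelier outcome.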

Compound 4, half-maximal inhibitory concentration: > 50000 nM
Compound 4 was reported as a limit; the forecaster's own chance of this, stated with the estimate: 80%; the middle value lies beyond the limit too.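

In this assay, the four-membered non-aromatic ring of compound 3 proves unnecessary for reaching the limit: compound 4 has a carboxylic acid on an open chain with no ring and 2 defined stereocentres, and its value is also a limit: the limit of > 50000 nM in this assay, at which 3 of the 4 values shown sit. Going by these compounds alone, the one step that can be read is an at least 1.0-fold higher number from compound 1 to compound 4 (0.03 log units; that floor lies within the scatter). The other two steps to compound 4 cannot be read, so this position has now taken a third amine side chain without any change beyond the scatter.

The limits leave open how compound 2, compound 3 and compound 4 rank against one another. Going by these compounds, it also remains open whether a simple dimethylamino group or a longer chain ending in a carboxylic acid, placed on the same saturated chain carbon bound to an aromatic carbon, would give a measurable number in this assay.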